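The source may report more compounds than this note shows. Statements on the series, on what has been measured and on what is new or still open speak of the compounds shown alone.

Compound 3 `CCN(C(=O)c1ccccc1COc1ccccc1)[C@@H]1CCC[C@H](N)C1` stands lowest of the two numbers in an assay on HEK293 cells for inhibition of transient receptor potential cation channel subfamily M member 8 (Homo sapiens), read by FLIPR and calcium flux; a higher number here means a weaker inhibitor, a lower number a stronger inhibitor: compound 3 gives 280 nM, while its nearest neighbour, compound 2 `CCN(C(=O)c1ccccc1OCc1ccccc1)C1CCCNC1`, gives 4860 nM. Compound 1 `CCN(C(=O)c1ccccc1OCc1ccccc1)[C@@H]1CC[C@H](N)C1` returns only a limit in this assay, > 5000 nM. Among the measured compounds shown here, the single measured step, an at least 1.0-fold lower number from compound 1 to compound 2 (0.01 log units; that floor lies within the scatter), concerns a different place in the molecule. Compound 4 `CCN(C(=O)c1ccccc1Cc1ccccc1)[C@@H]1CCC[C@H](N)C1` differs from compound 3 in one place: phenyl in place of phenoxy on a saturated chain carbon bound to an aromatic carbon. For the measured compounds named here, no measured step bears on this change, so the expectation rests on the value of compound 3 alone, and a step of a 1.8-fold higher number from compound 3 to compound 4 (0.25 log units; within the scatter) in this assay is expected, a modest drift toward a higher number that may not exceed the scatter. For compound 4 the estimate in this assay is 500 nM, between 100 nM and 3000 nM.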

Compound 4, antagonist equilibrium constant: > 2000 nM
Compound 4 ended at the assay's limit (the forecaster's own chance of this, stated with the estimate: 10%); middle value at least 4.0-fold (0.60 log units) away from the limit.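

In this assay, replacing phenoxy with phenyl on a saturated chain carbon bound to an aromatic carbon costs clear inhibition, unlike anything the earlier step could show, as it concerned a different place: an at least 7.1-fold higher number from compound 3 to compound 4 (0.85 log units; beyond the scatter). That step is only a floor, since the result for compound 4 is a limit of the assay: the limit of > 2000 nM in this assay, at which 1 of the 4 values shown sits. The two groups differ by the oxygen of phenoxy, so this place does not tolerate its simple removal.

On these data alone, it remains open whether the oxygen itself matters or the length of the chain. Phenylthio or a longer chain such as phenethyl at this place could separate the two.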